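Swapping a pyridylmethyl arm for a piperidinylethyl arm

The compounds below may be only part of what the source reports. "The series", "measured", "known", "first", "only" and "open" are said of these compounds alone.

Measured compounds in an assay on HEK293 cells for inhibition of Steryl-sulfatase (Homo sapiens), tested at 1 uM; a higher number here means a stronger effect of the compound at the concentration tested, a lower number a weaker effect:
compound 1 `CCN(Cc1ccccn1)c1ccc(C(=O)N2CCc3ccc(OS(N)(=O)=O)cc3C2)cc1` gives 87.7%
compound 2 `CCN(Cc1ccc(Br)cc1)c1ccc(C(=O)N2CCc3ccc(OS(N)(=O)=O)cc3C2)cc1` gives 95.9%
compound 3 `CCN(Cc1ccncc1)c1ccc(C(=O)N2CCc3ccc(OS(N)(=O)=O)cc3C2)cc1` gives 86.6%

Compound 3 gives the lowest of the three numbers, but its neighbours sit close: a number 1.1 percentage points lower from compound 1 to compound 3 (within the scatter) and a number 9.3 percentage points lower from compound 2 to compound 3 (within the scatter), so no order among the three can be claimed. The other step, a number 8.2 percentage points higher from compound 1 to compound 2 (within the scatter), is also within the scatter. All three compounds share the same core and differ only in the group on the saturated chain carbon bound to the nitrogen on the aromatic ring.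

Compound 4 `CN(CCN1CCCCC1)c1ccc(C(=O)N2CCc3ccc(OS(N)(=O)=O)cc3C2)cc1` is not yet measured. It differs from compound 3 as follows: methyl(2-(piperidin-1-yl)ethyl)amino in place of ethyl((pyridin-4-yl)methyl)amino on an aromatic carbon. Among the measured compounds shown here, none of the measured steps exchanges an aromatic ring for a non-aromatic one on this arm, so none bears directly on this change; they show only that the three variations tried so far left this assay essentially unchanged. On that basis compound 4 is expected to remain in the same region, with a step of about a number 1.6 percentage points lower from compound 3 to compound 4 (within the scatter), which is no change beyond the scatter. For the measured compounds named here, the estimate for compound 4 is therefore 85%, with a range from 65% to 97%, the wider spread reflecting that the entering group has no precedent here.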

Compound 4, a percentage reported as inhibition, at one concentration (the size of the read-out at that concentration, not a potency): 26.8%
Estimate against measurement, compound 4: 58.2 percentage points above; measured number below the stated range.
By their numbers in this assay, from the lowest: compound 4; then compounds 3, 1 and 2 (each within the scatter of the next).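

In this assay, this position proves not to be indifferent to the group it carries: the drop is a number 59.8 percentage points lower from compound 3 to compound 4 (beyond the scatter) and is matched by a number 60.9 percentage points lower from compound 1 to compound 4 (beyond the scatter) and a number 69.1 percentage points lower from compound 2 to compound 4 (beyond the scatter). The earlier ethyl arms, each bearing a six-membered aromatic ring, had stayed within the scatter of one another, whereas methyl(2-(piperidin-1-yl)ethyl)amino, with its six-membered non-aromatic ring, moves the read-out well beyond it, even though the entering and leaving groups of compound 3 and compound 4 match in heavy atoms, hydrogen-bond donors, hydrogen-bond acceptors and net charge. No measurement at hand offers a reason for this loss.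

The exchange alters several things at once, replacing ethyl with methyl on the nitrogen, lengthening the chain to the ring and replacing the aromatic ring with a non-aromatic one, so the compounds shown cannot assign the loss to any one of these. On these data alone, an ethyl(2-(pyridin-4-yl)ethyl)amino arm, a cyclohexylmethyl arm or a morpholin-4-yl group in place of piperidin-1-yl would each test one part of that exchange, and the effect of any of them at this position remains open.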